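Replacing an oxazole with piperidine on an unreadable baseline

A few compounds are considered here, and "the series" means these few. Any claim that something is new, unique, unknown or untested is made for them only; others in the source may bear on it.

Compound 3 `c1ccc(-c2cnco2)c(NCc2c[nH]cn2)c1` was tested in a functional assay for activation of Alpha-1B adrenergic receptor (Homo sapiens); on this read-out higher numbers stand for an effect only at larger amounts of compound and lower numbers for an effect already at smaller amounts. In this assay compound 3 gives < 5020 nM, which is a limit of the assay and not a number. Compound 2 `c1ccc(-c2cnco2)c(NCC2=NCCN2)c1` gives < 5020 nM, again only a limit. For the measured compounds named here, the one firm number comes from compound 1 `c1ccc(-c2ccno2)c(OCC2=NCCN2)c1`, which gives 100 nM. The step that the two limits leave unreadable from compound 2 to compound 3 therefore cannot be read, as the limit of < 5020 nM in this assay, at which 2 of the 3 values shown sit, shows.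

Compound 4 `c1ccc(N2CCCCC2)c(NCc2c[nH]cn2)c1` differs from compound 3 by piperidin-1-yl in place of 1,3-oxazol-5-yl on an aromatic carbon. Going by the values given here, no measured step swaps this kind of group, and the only compound sharing the change's surroundings, compound 3, sits at a limit, so the measured steps say nothing about its size or direction. With nothing to anchor it, compound 4 is expected to land near 3000 nM, within a wide range from 300 nM to 30000 nM, and the step that the limit leaves unreadable from compound 3 to compound 4 is an estimate only, with a real chance that compound 4 also returns a limit rather than a number.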

Compound 4, half-maximal effective concentration: < 5020 nM
Compound 4: only a limit was reported; the forecaster's own chance of this, stated with the estimate: 40%; the middle value is on the limit's open side.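

For the compounds shown here, compound 3 and compound 4 both give only a limit of the assay and not a number, so no step between them can be read: the limit of < 5020 nM in this assay, at which 3 of the 4 values shown sit. The compounds shown leave open whether piperidin-1-yl in place of 1,3-oxazol-5-yl changes the read-out at all, and in which direction.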